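Series notes: ring hydroxy removal on the shared core

This account rests on a few compounds, and the source may have more. Where it says the series, first, only, none or still open, it means among the compounds named here.

Measured compounds:
compound 1 `CCCCCCCCC#Cc1cc2cn([C@@H]3O[C@H](CO)[C@@H](O)[C@@H]3O)c(=O)nc2o1` gives in a functional assay on HEL cells (Homo sapiens) for cytotoxicity (on this read-out lower numbers stand for higher toxicity in this test and higher numbers for lower toxicity in this test), a limit of the assay, > 124000 nM.
compound 2 `CCCCCCC#Cc1cc2cn([C@@H]3O[C@H](CO)[C@@H](O)[C@@H]3O)c(=O)nc2o1` gives in this assay likewise only a limit, > 53000 nM.

Compound 2 therefore stands at a limit in this assay, not at a number. Compound 1 also sits at a limit, so a step that the two limits leave unreadable from compound 1 to compound 2 cannot be read. The change to compound 3 `CCCCCCC#Cc1cc2cn([C@H]3C[C@H](O)[C@@H](CO)O3)c(=O)nc2o1` is hydrogen in place of hydroxy on a saturated ring carbon. Within the data shown here, no measured step touches this ring position, and both measured values are limits, so the data give no size for it. Compound 3 is expected to remain at or near the limit. Compound 3 is estimated at 100000 nM, between 30000 nM and 300000 nM. The expected step is a step that the limit leaves unreadable from compound 2 to compound 3.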

Compound 3, half-maximal cytotoxic concentration: 138000 nM
The estimate for compound 3 lay 1.4-fold (0.14 log units) below the measured number; low and high end bracket the measured number.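

Among these compounds, compound 2 gives only a limit of the assay, > 53000 nM, and no step from it to compound 3 can be read. As far as these compounds go, whether hydrogen in place of hydroxy on the saturated ring carbon shifts the read-out in this assay at all, and by how much, stays open.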